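This account rests on a few compounds, and the source may have more. Where it says the series, first, only, none or still open, it means among the compounds named here.

Three compounds share one core and differ only in the group attached to one aromatic carbon of that core. Compound 1 `Sc1nc(NCc2ccccc2)c2ccccc2n1` carries a single sulfur atom there, while compound 2 `CCCCC[Se]c1nc(NCc2ccccc2)c2ccccc2n1` and compound 3 `C[Se]c1nc(NCc2ccccc2)c2ccccc2n1` carry selenium-bearing groups in its place. In a functional assay on HT-29 cells (Homo sapiens) for cytotoxicity, read by MTT assay, with a stated time of 72 h (a lower number here means that less compound is tolerated, a higher number that more compound is tolerated), compound 1 reports only a limit, > 100000 nM. In this assay compound 2 likewise reports only a limit, > 100000 nM. In this assay compound 3 also reports only a limit, > 100000 nM. Because of the limit of > 100000 nM in this assay, at which 3 of the 3 values shown sit, none of the steps among these three can be sized: a step that the two limits leave unreadable from compound 1 to compound 2, a step that the two limits leave unreadable from compound 1 to compound 3 and a step that the two limits leave unreadable from compound 2 to compound 3 all remain unreadable. Compound 3 therefore stands at the same limit as the two compounds around it, with no readable distance to either.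

Compound 4 `CSc1nc(NCc2ccccc2)c2ccccc2n1` is reached from compound 3 by a group of 2 heavy atoms (1 carbon, 1 sulfur; no ring) in place of a group of 2 heavy atoms (1 carbon, 1 selenium; no ring), on an aromatic carbon. Within the data shown here, no measured step bears on this exchange in a readable way, since every value so far is a limit, and compound 1 with its plain sulfur atom also sits there. On this footing the step of a number no higher from compound 3 to compound 4 (the limit leaves the size open) is expected to be none beyond the scatter. Compound 4 is accordingly expected to give about 100000 nM in this assay, in a range from 50000 nM to 200000 nM, most likely again as a limit rather than a number.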

Compound 4, concentration lethal to 50% of the cells: > 100000 nM
Compound 4: only a limit was reported; the forecaster's own chance of this, stated with the estimate: 85%; the middle value sits exactly at the limit.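

Compound 4 reports only a limit in this assay, so no step among compound 1, compound 2, compound 3 and compound 4 can be read, for one reason: the limit of > 100000 nM in this assay, at which 4 of the 4 values shown sit. The compounds shown leave open whether exchanging selenium for sulfur, or changing the chain on it, makes any difference in this assay.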